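A Pyrrolidinylmethyl Group Added to an Anilide

This account rests on a few compounds, and the source may have more. Where it says the series, first, only, none or still open, it means among the compounds named here.

Three compounds share one core and differ only in the substituent on the amide nitrogen. In an ADME assay on BaF3 cells (Mus musculus) for antiproliferative activity, read by CCK-8 assay, with a stated time of 72 h (on this read-out higher numbers stand for weaker inhibition of growth and lower numbers for stronger inhibition of growth), compound 1 `O=C(CCSc1ccc2c(/C=C/c3ccccn3)n[nH]c2c1)Nc1cccc(Cl)c1` gives 9350 nM. Compound 2 `O=C(CCSc1ccc2c(/C=C/c3ccccn3)n[nH]c2c1)Nc1cccc(C(F)(F)F)c1` gives 2300 nM, and compound 3 `O=C(CCSc1ccc2c(/C=C/c3ccccn3)n[nH]c2c1)NCc1cccc(C(F)(F)F)c1` gives 8030 nM. Compound 2 stands lowest of the three numbers: the step of a 4.1-fold lower number from compound 1 to compound 2 (0.61 log units; beyond the scatter) moved beyond the scatter, as did a 3.5-fold higher number from compound 2 to compound 3 (0.54 log units; beyond the scatter), whereas a 1.2-fold lower number from compound 1 to compound 3 (0.07 log units; within the scatter) stayed within it.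

Compound 4 `O=C(CCSc1ccc2c(/C=C/c3ccccn3)n[nH]c2c1)Nc1ccc(CN2CCCC2)c(C(F)(F)F)c1` has not yet been measured. It differs from compound 2 by (pyrrolidin-1-yl)methyl in place of hydrogen on an aromatic carbon. For the measured compounds named here, none of the measured steps bears on this change: each of them either exchanges the group attached to the amide nitrogen or swaps chloro for trifluoromethyl, while compound 4 keeps the 3-(trifluoromethyl)phenyl of compound 2 unchanged and adds a (pyrrolidin-1-yl)methyl group on that ring, ortho to the trifluoromethyl group. Going by the values given here, with no comparable step among the measured compounds, the expected step of a 1.5-fold lower number from compound 2 to compound 4 (0.19 log units; within the scatter) in this assay is placed close to the scatter, with a wide range on either side. Compound 4 is therefore estimated at 1500 nM, within a range from 400 nM to 6000 nM.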

Compound 4, concentration for 50% growth inhibition: 4000 nM
The estimate for compound 4 lay 2.7-fold (0.43 log units) below the measured number, and the stated range covers the measured number.
By their numbers in this assay, from the lowest: compounds 2, 4, 3 and 1 (each within the scatter of the next, the first and the last beyond it).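

In this assay the step of a 1.7-fold higher number from compound 2 to compound 4 (0.24 log units; within the scatter) stays within the scatter, so adding (pyrrolidin-1-yl)methyl, with its five-membered non-aromatic ring, left no change that this read-out can separate from repeat variation. For the compounds shown here, this is the first information about this position on the aromatic ring, ortho to a trifluoromethyl group and para to a large group: the earlier steps concerned only the chloro-to-trifluoromethyl exchange and the group on the amide nitrogen, and two of those moved beyond the scatter, whereas this larger addition on the ring of compound 2 did not. Going by these compounds alone, no available evidence accounts for this result, and the single step gives only its size.

A single substituent at a single position leaves open whether a morpholine, a 4-methylpiperazine or an open-chain dimethylamino group on the same methyl link would give a similar number, and whether a longer chain between the ring and the amine would do so. As far as these compounds go, it also remains open whether (pyrrolidin-1-yl)methyl would behave in the same way on the chloro-substituted ring of compound 1 or on the benzyl group of compound 3.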